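Piperazine for piperidine on the shared core

The source may hold more compounds than are shown below. What is called first, only, known or untested is meant among the compounds shown, and "the series" means these compounds.

Compound 1 `Fc1ccccc1Cn1nc(-c2ncc(F)c(N3CCCCC3)n2)cc1-c1ccon1` carries a piperidin-1-yl group on its core. In an ADME assay on microsomes from liver (Rattus norvegicus) for pharmacokinetics (on this read-out higher numbers stand for fast clearance and lower numbers for slow clearance), compound 1 gives 490 uL/min, the highest of the two numbers in hand. Compound 2 `OC1CCN(c2nc(-c3cc(-c4ccon4)n(Cc4ccccc4F)n3)ncc2F)CC1` differs from it in one place, hydroxy in place of hydrogen on a saturated ring carbon, and in this assay compound 2 gives 390 uL/min; the step of a 1.3-fold lower number from compound 1 to compound 2 (0.10 log units; within the scatter) leaves the two within the scatter of each other.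

Compound 3 `Fc1ccccc1Cn1nc(-c2ncc(F)c(N3CCNCC3)n2)cc1-c1ccon1` is not yet measured. It differs from compound 1 by piperazin-1-yl in place of piperidin-1-yl on an aromatic carbon.

For the measured compounds named here, the only measured step that bears on this change is the one from compound 1 to compound 2, where the change also sits on a saturated ring and a 1.3-fold lower number from compound 1 to compound 2 (0.10 log units; within the scatter) is small. On that basis no step beyond the scatter is expected for compound 3 in this assay, with at most a slight lean toward a lower number. The expected step is a 1.2-fold lower number from compound 1 to compound 3 (0.09 log units; within the scatter). Compound 3 is therefore estimated to give 400 uL/min in this assay, within a range of 200 uL/min to 800 uL/min.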

Compound 3, intrinsic clearance in a liver preparation (reported as CLH), per the amount of preparation that the assay uses: 72 uL/min
Compound 3: middle estimate off by 5.6-fold (0.74 log units), on the high side; measured number outside the range, below it.
By their numbers in this assay, from the lowest: compound 3; then compounds 2 and 1 (each within the scatter of the next).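

In this assay, the group on the aromatic carbon next to the ring nitrogen and ortho to a fluoro group can clearly move the read-out. Piperazin-1-yl in place of piperidin-1-yl gives a step beyond the scatter (a 6.8-fold lower number from compound 1 to compound 3 (0.83 log units; beyond the scatter)), whereas hydroxy on a saturated ring carbon gave only a step within it (a 1.3-fold lower number from compound 1 to compound 2 (0.10 log units; within the scatter)), so the earlier pair gave no sign of how far this position could shift the number. Piperazin-1-yl in place of 4-hydroxypiperidin-1-yl gives a similar result (a 5.4-fold lower number from compound 2 to compound 3 (0.73 log units; beyond the scatter)), which leaves compound 3 with the lowest number of the three, and no measurement in hand accounts for this step.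

The compounds shown cannot separate the effect of the second ring nitrogen from that of the hydrogen it carries, and 4-methylpiperazin-1-yl or morpholin-4-yl at this position would address that question directly. They also leave open whether the step from piperidin-1-yl to piperazin-1-yl carries over when the fluoro group, the 2-fluorobenzyl group or the other groups on the shared core are changed.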